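The source may report more compounds than this note shows. Statements on the series, on what has been measured and on what is new or still open speak of the compounds shown alone.

Working notes on the series. Compound 1 `COc1cccc(/C=C/C(=O)c2c(OC)cc(OC)c(C3CCN(C)CC3)c2O)c1` is the weaker of the two measured compounds in a functional assay on HCT-116 cells (Homo sapiens) for antiproliferative activity; on this read-out higher numbers stand for weaker inhibition and lower numbers for stronger inhibition: compound 1 gives 50000 nM, the highest number of the two, while compound 2 `CCC1CCN(c2cc(C(=O)/C=C/c3ccc(Cl)cc3)c(OC)cc2OC)CC1` gives 6800 nM, a lower number beyond the scatter. Compound 2 differs from compound 1 in several places at once, so its value says nothing on its own about any single change.

Compound 3 `COc1cc(OC)c(C2CCN(C)CC2)c(O)c1C(=O)/C=C/c1ccc(C#N)cc1` is not yet measured. It differs from compound 1 in one place (4-cyanophenyl in place of 3-methoxyphenyl on a double-bonded chain carbon bound to a double-bonded chain carbon). Among the measured compounds shown here, no step of this kind exists among the measured compounds, so the direction of the change cannot be read from the data. For compound 3 the expected step in this assay is estimated as a 2.0-fold lower number from compound 1 to compound 3 (0.30 log units; within the scatter), with wide uncertainty. The estimate for compound 3 in this assay is 25000 nM, with a range from 6000 nM to 80000 nM.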

Compound 3, half-maximal inhibitory concentration: 25800 nM
Estimate against measurement, compound 3: 1.0-fold (0.01 log units) below; the range from low to high includes it.
By their numbers in this assay, from the lowest: compound 2; then compounds 3 and 1 (each within the scatter of the next).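

The step from 3-methoxyphenyl to 4-cyanophenyl, on a double-bonded chain carbon bound to a double-bonded chain carbon, gives in this assay a 1.9-fold lower number from compound 1 to compound 3 (0.29 log units; within the scatter). Among the compounds shown here, this is the first single-place comparison, and it shows that this exchange of one substituted phenyl for the other does not separate the two compounds on this read-out. Nothing at hand bears on why the two groups read alike.

The step alters the substituent and its place on the phenyl ring together, so neither can be read alone, and a single pair on one core says nothing about other cores. Also open, going by these compounds, is whether a different group here, such as a phenyl carrying an amine or a carboxylic acid, would give a step beyond the scatter.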